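The source may report more compounds than this note shows. Statements on the series, on what has been measured and on what is new or still open speak of the compounds shown alone.

Three compounds have been measured in an assay on isolated protein for inhibition of Amine oxidase [flavin-containing] B (Homo sapiens), read by fluorescence, with stated times of 15 min and 20 min; on this read-out higher numbers stand for weaker inhibition and lower numbers for stronger inhibition:

Compound 1 `Cc1ccccc1CN1CCC(CCNC(=O)/C=C/c2cc(C(C)(C)C)c(O)c(C(C)(C)C)c2)CC1`: 7200 nM
Compound 2 `Cc1ccc(CN2CCC(CCNC(=O)/C=C/c3cc(C(C)(C)C)c(O)c(C(C)(C)C)c3)CC2)cc1`: 8900 nM
Compound 3 `CC(C)(C)c1cc(/C=C/C(=O)NCCC2CCN(Cc3ccc(Br)cc3)CC2)cc(C(C)(C)C)c1O`: 13200 nM

Compound 3 shows the highest of the three numbers, but its gaps to compound 2 and to compound 1 both lie within the scatter, so no order among the three can be claimed. Compound 4 `CC(C)(C)c1cc(/C=C/C(=O)NCCC2CCN(Cc3cccc([N+](=O)[O-])c3)CC2)cc(C(C)(C)C)c1O` differs from compound 3 by 3-nitrophenyl in place of 4-bromophenyl on a saturated chain carbon bound to an amine nitrogen in a ring. Within the data shown here, every measured step so far alters the group on that same carbon: a 1.2-fold higher number from compound 1 to compound 2 (0.09 log units; within the scatter), a 1.8-fold higher number from compound 1 to compound 3 (0.26 log units; within the scatter) and a 1.5-fold higher number from compound 2 to compound 3 (0.17 log units; within the scatter), each within the scatter. Among the measured compounds shown here, no measured compound carries a nitro group, so the step is less well anchored, but on these data a change of a 1.1-fold lower number from compound 3 to compound 4 (0.04 log units; within the scatter) in this assay is expected, not beyond the scatter. Compound 4 is therefore estimated at 12000 nM, with a range from 4000 nM to 36000 nM.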

Compound 4, half-maximal inhibitory concentration: 12500 nM
Compound 4: middle estimate off by 1.0-fold (0.02 log units), on the low side; the measured number falls inside the stated range.
By their numbers in this assay, from the lowest: compounds 1, 2, 4 and 3 (each within the scatter of the next).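

In this assay, 3-nitrophenyl in place of 4-bromophenyl gives a 1.1-fold lower number from compound 3 to compound 4 (0.02 log units; within the scatter), and 3-nitrophenyl gives a 1.4-fold higher number from compound 2 to compound 4 (0.15 log units; within the scatter) against 4-methylphenyl and a 1.7-fold higher number from compound 1 to compound 4 (0.24 log units; within the scatter) against 2-methylphenyl. Among these compounds, this is the first nitro group at this position, and with its 2 hydrogen-bond acceptors it still gives no step beyond the scatter, so all four compounds remain indistinguishable here. No measured evidence is available to explain this result. Going by these compounds, whether an amine or a carboxylic acid on this phenyl ring, or a longer chain in place of the benzyl carbon, would move the number beyond the scatter remains open.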